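The source may hold more compounds than are shown below. What is called first, only, known or untested is meant among the compounds shown, and "the series" means these compounds.

Measured in a functional assay on MCF7 cells (Homo sapiens) for cytotoxicity, read by sulforhodamine B assay, with a stated time of 48 h; a higher number here means a weaker inhibitor, a lower number a stronger inhibitor:
Compound 1 `S=c1[nH]nc(Cn2c(-c3ccco3)nc3ccccc32)s1` (52600 nM)
Compound 2 `SC1=NNCC(n2c(-c3ccco3)nc3ccccc32)=N1` (60500 nM)

These two numbers lie within the scatter of each other, so compound 2 stands level with compound 1, and neither can be ranked above the other. Compound 3 `N=C1N=C(n2c(-c3ccco3)nc3ccccc32)CN1` alters the group on an aromatic nitrogen of the shared core, and the difference from compound 2 is this: a group of 6 heavy atoms (3 carbon, 3 nitrogen; one five-membered non-aromatic ring with 2 hetero atoms) in place of a group of 7 heavy atoms (3 carbon, 3 nitrogen, 1 sulfur; one six-membered non-aromatic ring with 3 hetero atoms), on an aromatic nitrogen. In compound 3, a five-membered non-aromatic ring with 2 hetero atoms therefore takes the place of the six-membered non-aromatic ring with 3 hetero atoms.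

Among the compounds with values here, only one measured step bears on this change. That step, a 1.2-fold higher number from compound 1 to compound 2 (0.06 log units; within the scatter), also exchanged the group at this nitrogen, and it stayed within the scatter. Within the data shown here, it is thin evidence, and no measured compound carries the entering group. Even so, the only precedent gives no reason to expect a real shift, so the expected step, a 1.1-fold lower number from compound 2 to compound 3 (0.04 log units; within the scatter), is none beyond the scatter, with no firm direction. The estimated value for compound 3 is 55000 nM (22000 nM to 130000 nM).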

Compound 3, half-maximal inhibitory concentration: 93000 nM
Compound 3: the middle estimate sits 1.7-fold (0.23 log units) below what was measured, and the stated range covers the measured number.
By their numbers in this assay, from the lowest: compounds 1, 2 and 3 (each within the scatter of the next).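

In this assay, a third kind of ring on this aromatic nitrogen still gives no separation: a 1.5-fold higher number from compound 2 to compound 3 (0.19 log units; within the scatter), and a 1.8-fold higher number from compound 1 to compound 3 (0.25 log units; within the scatter). The group in compound 3 is a five-membered non-aromatic ring with 2 hetero atoms and holds no sulfur, whereas the groups in compound 1 and compound 2 each hold sulfur, so across these three compounds neither the sulfur, nor the ring size, nor whether the ring is aromatic goes with a change beyond the scatter. Nothing available explains this flat result, and no independent measurement bears on why these groups sit level.

Going by these compounds, all three groups at this position are rings, so it remains open whether an open-chain amine, a carboxylic acid or a longer chain on this nitrogen would give a number beyond the scatter. Also open, on these data alone, is what happens when the furan-2-yl group, which all three compounds carry, is replaced by another group such as a phenyl ring.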